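From a Benzylamide to a Free Acid in Compound 4

The source may hold more compounds than are shown below. What is called first, only, known or untested is meant among the compounds shown, and "the series" means these compounds.

Compound 1 `COc1ccc(C(=O)/C=C/c2ccc(C(=O)NCc3ccccc3)cc2)c(O)c1` was tested in an ADME assay on SH-SY5Y cells (Homo sapiens) for cytotoxicity, read by MTT assay, with a stated time of 48 h; a lower number here means a stronger inhibitor, a higher number a weaker inhibitor. In this assay compound 1 gives only a limit, > 100000 nM. Compound 2 `COc1ccc(C(=O)/C=C/c2cc(OC)c(OC)cc2OC)c(O)c1` likewise gives only a limit in this assay, > 100000 nM. Compound 3 `CCCCCCCCCCCCNC(=O)c1ccc(/C=C/C(=O)c2ccc(OC)cc2O)cc1` also gives only a limit in this assay, > 100000 nM. Within the data shown here, the single step between measured compounds that differ in one place, a step that the two limits leave unreadable from compound 1 to compound 3, cannot be read because both sit at the limit of > 100000 nM in this assay, at which 3 of the 3 values shown sit. Compound 4 `COc1ccc(C(=O)/C=C/c2ccc(C(=O)O)cc2)c(O)c1` differs from compound 1 by hydroxy in place of benzylamino on a carbonyl carbon. Among the measured compounds shown here, no measured step touches this change, and all three values shown are limits, so no direction beyond the scatter can be expected. Compound 4 is therefore expected to give about 150000 nM, within 50000 nM to 500000 nM, most likely again as a limit. This expectation amounts to a step that the limit leaves unreadable from compound 1 to compound 4.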

Compound 4, half-maximal inhibitory concentration: > 100000 nM
Compound 4 was reported as a limit; the forecaster's own chance of this, stated with the estimate: 85%; the middle value lies beyond the limit too.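

Compound 1 and compound 4 both give only a limit, not a number, so the step between them cannot be read: the limit of > 100000 nM in this assay, at which 4 of the 4 values shown sit.

The compounds shown leave open whether hydroxy in place of benzylamino changes the read-out at all, and at what concentration any of them would reach half-maximal inhibition.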